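Step from compound 3 to compound 4 in this series

A few compounds are considered here, and "the series" means these few. Any claim that something is new, unique, unknown or untested is made for them only; others in the source may bear on it.

In an assay on isolated protein for inhibition of Beta-glucosidase (Homo sapiens) (a lower number here means a stronger inhibitor, a higher number a weaker inhibitor), the measured compounds stand as follows:
compound 1 `Cc1cccc(-c2ccc(COCCCCCN3C[C@H](O)[C@@H](O)[C@H](O)[C@H]3CO)cc2)c1` gives 2 nM
compound 2 `COc1cccc(-c2ccc(COCCCCCN3C[C@H](O)[C@@H](O)[C@H](O)[C@H]3CO)cc2)c1` gives 20 nM
compound 3 `OC[C@@H]1[C@@H](O)[C@H](O)[C@@H](O)CN1CCCCCOCc1ccc(-c2ccnc(F)c2)cc1` gives 4 nM

Compound 3 holds the second highest of the three numbers. Its nearest neighbour is compound 1: the step of a 2.0-fold higher number from compound 1 to compound 3 (0.30 log units; within the scatter) stays within the scatter, so the two cannot be ordered. Its furthest neighbour is compound 2: the step of a 5.0-fold lower number from compound 2 to compound 3 (0.70 log units; beyond the scatter) lies beyond the scatter.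

Compound 4 `OC[C@@H]1[C@@H](O)[C@H](O)[C@@H](O)CN1CCCCCOCc1ccc(-c2ccc(F)nc2)cc1` differs from compound 3 only in the distal aromatic group: 6-fluoropyridin-3-yl in place of 2-fluoropyridin-4-yl on an aromatic carbon. The same atoms are joined differently; nothing is added or removed.

For the measured compounds named here, no measured step tests this kind of rearrangement. Going by the values given here, the steps that exist change what sits on the distal ring: a 10-fold higher number from compound 1 to compound 2 (1.00 log units; beyond the scatter) is the only step beyond the scatter between two compounds with a carbon-only distal ring, and a 2.0-fold higher number from compound 1 to compound 3 (0.30 log units; within the scatter) shows that exchanging the whole distal group for the 2-fluoropyridin-4-yl group changed little. Among the compounds with values here, with no step that bears directly on the isomer swap, the expectation for this assay is a step of no more than the scatter, and the expected step is a 1.3-fold higher number from compound 3 to compound 4 (0.10 log units; within the scatter). Compound 4 is therefore estimated at 5 nM, in the range 2 nM to 15 nM.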

Compound 4, half-maximal inhibitory concentration: 5 nM
Estimate against measurement, compound 4: no gap at the digits printed; measured number inside the range.
By their numbers in this assay, from the lowest: compounds 1, 3 and 4 (each within the scatter of the next, the first and the last beyond it); then compound 2.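

For the compounds shown here, the isomer swap on the aromatic carbon para to a large group gives a 1.3-fold higher number from compound 3 to compound 4 (0.10 log units; within the scatter) in this assay, so 6-fluoropyridin-3-yl and 2-fluoropyridin-4-yl cannot be ordered, and this is the first direct reading of a rearrangement within the distal ring at this place. The second fluoropyridine keeps the separation from the 3-methoxyphenyl compound, with a 4.0-fold lower number from compound 2 to compound 4 (0.60 log units; beyond the scatter), but against the 3-methylphenyl compound it gives a 2.5-fold higher number from compound 1 to compound 4 (0.40 log units; beyond the scatter), a modest step beyond the scatter that a 2.0-fold higher number from compound 1 to compound 3 (0.30 log units; within the scatter) did not reach, although compound 3 and compound 4 themselves cannot be told apart. No measurement at hand accounts for any of these steps.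

The compounds shown leave open whether the fluorine or the ring nitrogen matters more here, which an unsubstituted pyridin-3-yl or a 6-chloropyridin-3-yl group would help to separate. As far as these compounds go, it also remains open whether a distal ring carrying an amine or a carboxylic acid would stay in the same range in this assay.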